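Moving the carboxylic acid around the distal ring

The source may hold more compounds than are shown below. What is called first, only, known or untested is meant among the compounds shown, and "the series" means these compounds.

Compound 1 `Cc1c(OCCCCOc2ccccc2C(=O)O)ccc(C(=O)CC(C)C)c1O` is the reference point here. In an assay on HEK293 cells for positive allosteric modulation of metabotropic glutamate receptor 2 (Rattus norvegicus), read by thallium flux, with a stated time of 2.5 min (a lower number here means that less compound is needed, a higher number that more compound is needed for the effect), compound 1 gives 415 nM, the lowest of the three numbers shown. Compound 2 `Cc1c(OCCCCOc2ccc(C(=O)O)cc2F)ccc(C(=O)CC2CCCC2)c1O` gives 639 nM, and compound 3 `Cc1c(OCCCCOc2ccccc2C(=O)O)ccc(C(=O)CC(C)C)c1C` gives 976 nM. Among the measured compounds shown here, the only step between neighbours that differ in one place is a 2.4-fold higher number from compound 1 to compound 3 (0.37 log units; beyond the scatter), a change on the core that does not touch the distal ring.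

Compound 4 `Cc1cc(OCCCCOc2ccc(C(=O)CC(C)C)c(O)c2C)ccc1C(=O)O` differs from compound 1 in 4-carboxy-3-methylphenyl in place of 2-carboxyphenyl on an oxygen on a saturated carbon. For the measured compounds named here, no measured step speaks to this change directly. Compound 2 carries its carboxylic acid on a differently substituted ring and also a different ketone side chain, so it is not a clean comparison, but its value and that of compound 1 lie within the usual scatter of each other, which suggests that the position and decoration of the distal carboxyphenyl are tolerated without a large swing. For compound 4 the expected step is therefore a 1.4-fold higher number from compound 1 to compound 4 (0.16 log units; within the scatter), a shift no larger than the scatter, with a slight lean toward a higher number. Compound 4 is estimated at 600 nM in this assay, with a likely range from 250 nM to 1500 nM.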

Compound 4, half-maximal effective concentration: 173 nM
The estimate for compound 4 lay 3.5-fold (0.54 log units) above the measured number; the whole stated range lies above it.
By their numbers in this assay, from the lowest: compound 4; then compounds 1, 2 and 3 (each within the scatter of the next, the first and the last beyond it).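

The swap of 2-carboxyphenyl for 4-carboxy-3-methylphenyl on the oxygen gives a 2.4-fold lower number from compound 1 to compound 4 (0.38 log units; beyond the scatter) in this assay, so this position on the chain does more than tolerate a change: here the change goes with a number beyond the scatter, and compound 4, at 173 nM, has the lowest number of the set. Among the compounds shown here, until now the only clean step was on the core and went toward a higher number, so this is the first clean evidence that the distal ring itself can move the number, and that it can move it down. Nothing available explains why this replacement gives a lower number, and no measurement of any property of these compounds bears on it.

The replacement moves the carboxylic acid and adds a methyl in one step, so the compounds shown cannot assign the gain to either part, and a plain 4-carboxyphenyl on the same oxygen would separate the two. On these data alone, it also remains open whether a tetrazole or an amide could take the place of the carboxylic acid on this ring, and whether a longer chain would keep the lower number.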